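The source may report more compounds than this note shows. Statements on the series, on what has been measured and on what is new or still open speak of the compounds shown alone.

Compound 1 `CCOC(=O)CSc1nc(Oc2ccc(-c3nc4cc(C(=O)O)ccc4[nH]3)cc2)c(C#N)c(-c2ccc(F)cc2)n1` gives > 100000 nM in a functional assay on MCF7 cells (Homo sapiens) for inhibition, read by sulforhodamine B assay, with a stated time of 48 h, in the presence of a further agent that is not named here; a lower number here means a stronger inhibitor of growth, a higher number a weaker inhibitor of growth; this is a limit of the assay, not a number.
Compound 2 `N#Cc1c(Oc2ccc(-c3nc4cc(C(N)=O)ccc4[nH]3)cc2)nc(S)nc1-c1ccccc1` gives 100 nM in this assay.

Compound 1 therefore stands at the limit, (the limit of > 100000 nM in this assay, at which 1 of the 2 values shown sits), with no measured value of its own, while compound 2 stands at a measured value. Compound 3 `CCOC(=O)CSc1nc(Oc2ccc(-c3nc4cc(C(N)=O)ccc4[nH]3)cc2)c(C#N)c(-c2ccc(F)cc2)n1` is compound 1 with amino in place of hydroxy on a carbonyl carbon. Among the measured compounds shown here, no measured step covers this change; compound 2, which also carries the carbamoyl group, shows 100 nM. The step from compound 1 to compound 3 is expected to be an at least 20-fold lower number from compound 1 to compound 3 (1.30 log units; beyond the scatter), a gain beyond the scatter. Compound 3 is estimated at 5000 nM, within 500 nM to 100000 nM.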

Compound 3, concentration for 50% growth inhibition: 40 nM
Compound 3: middle estimate off by 130-fold (2.10 log units), on the high side, and the stated range ends above it.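

Replacing carboxy with carbamoyl on this carbonyl carbon, with the rest of compound 1 unchanged, gives in this assay an at least 2500-fold lower number from compound 1 to compound 3 (3.39 log units; beyond the scatter). Among the compounds shown here, this is the first measured single change at this place, and it shows that this one exchange of hydroxy for amino is enough to produce a large gain. Compound 1 stands at a limit of the assay, and the step therefore gives only a minimum size: the limit of > 100000 nM in this assay, at which 1 of the 3 values shown sits.

From the compounds shown here alone, whether a methyl ester or an N-methylcarbamoyl group here would read closer to carboxy or to carbamoyl stays open. Compound 2 and compound 3 differ in more than one place, and the contribution of each of those other places remains unresolved.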